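This account rests on a few compounds, and the source may have more. Where it says the series, first, only, none or still open, it means among the compounds named here.

In a functional assay on Jurkat cells (Homo sapiens) for inhibition, read by CCK-8 assay, with a stated time of 48 h (on this read-out higher numbers stand for weaker inhibition of growth and lower numbers for stronger inhibition of growth), compound 1 (`CN1CCN(c2ccc(Nc3ncc(Cl)c(NCc4ccc(F)cc4)n3)nc2)CC1`) gives > 100000 nM, which is a limit of the assay and not a number. Among the measured compounds shown here, compound 2 (`COc1cccc(CNc2nc(Nc3ccc(N4CCN(C)CC4)cn3)ncc2Cl)c1`) gives 73400 nM, the only true number so far. In compound 3 (`CCc1ccc(Nc2nc(Nc3ccc(N4CCN(C)CC4)cn3)ncc2Cl)cc1`), 4-ethylphenyl sits in place of 3-methoxybenzyl on a nitrogen on an aromatic ring: 4-ethylphenyl in place of 3-methoxybenzyl on a nitrogen on an aromatic ring. For the measured compounds named here, the one measured step that bears on this change is an at least 1.3-fold lower number from compound 1 to compound 2 (0.13 log units; that floor lies within the scatter), so it offers only weak guidance. A modest move towards stronger inhibition is expected, with much uncertainty, and the expected change is a 2.1-fold lower number from compound 2 to compound 3 (0.32 log units; beyond the scatter). For compound 3 the estimated value is 35000 nM, within an expected range of 6000 nM to 100000 nM.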

Compound 3, concentration for 50% growth inhibition: 11100 nM
Estimate against measurement, compound 3: 3.2-fold (0.50 log units) above; measured number inside the range.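

In this assay the group on this nitrogen can move the read-out beyond the scatter: 4-ethylphenyl in place of 3-methoxybenzyl gives a 6.6-fold lower number from compound 2 to compound 3 (0.82 log units; beyond the scatter). Set against 4-fluorobenzyl, the same group gives an at least 9.0-fold lower number from compound 1 to compound 3 (0.95 log units; beyond the scatter). That second step is only a floor, since compound 1 stands at a limit: the limit of > 100000 nM in this assay, at which 1 of the 3 values shown sits.

Going by these compounds, the change alters both the ring's substituent and the carbon linking that ring to the nitrogen, so the source of the gain stays open. A 4-ethylbenzyl or a 3-methoxyphenyl group on this nitrogen would separate the two.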